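A few compounds are considered here, and "the series" means these few. Any claim that something is new, unique, unknown or untested is made for them only; others in the source may bear on it.

In a functional assay on SW480 cells (Homo sapiens) for antiproliferative activity, read by MTT assay, with a stated time of 48 h (a higher number here means a weaker inhibitor, a lower number a stronger inhibitor), compound 1 `CCCCCC(CCO)n1cnc2c(OC)ncnc21`, which carries a methoxy group, reads > 50000 nM, and this is a limit of the assay, not a number. For the measured compounds named here, compound 2 `CCCCCCC(CCO)n1cnc2c(Cl)ncnc21` gives 16700 nM, the only true number so far. Compound 3 `CCCCCCC(CCO)n1cnc2c(OC)ncnc21` departs from compound 2 by a single change, methoxy in place of chloro on an aromatic carbon, opposite the ring nitrogen. Going by the values given here, no measured step between compounds differing in one place is available to size this change, so the expectation rests on a single reading. Compound 1 shows > 50000 nM, again a limit, and on that basis a moderate shift toward weaker inhibition is expected in this assay. The expected step is a 2.3-fold higher number from compound 2 to compound 3 (0.36 log units; beyond the scatter). Compound 3 is estimated at 38000 nM, within an expected range of 17000 nM to 85000 nM.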

Compound 3, half-maximal inhibitory concentration: > 50000 nM
Compound 3: a limit, no number; the forecaster's own chance of this, stated with the estimate: 45%; middle value at least 1.3-fold (0.11 log units) away from the limit.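

Methoxy in place of chloro on this aromatic carbon, opposite the ring nitrogen, could now be sized for the first time with the chain held the same, and in this assay the change gives an at least 2.9-fold higher number from compound 2 to compound 3 (0.47 log units; beyond the scatter). This is only a lower bound, since compound 3 reads as a limit and not a number, and the step from compound 1 to compound 3 cannot be read. Chloro thus remains the only group at this position with a true number, and the methoxy readings stop at the same ceiling: the limit of > 50000 nM in this assay, at which 2 of the 3 values shown sit.

The compounds shown leave open how much weaker compound 3 really is. They also leave open whether an amine or a bromine atom on this carbon would keep a readable value, and what a longer chain would do with chloro in place.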